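Ethoxy to trifluoromethoxy on a quinolinecarboxamide core

The compounds below may be only part of what the source reports. "The series", "measured", "known", "first", "only" and "open" are said of these compounds alone.

Measured compounds:
compound 1 `Cc1c(C(=O)Nc2c(F)cc(-c3cccc(F)c3)cc2F)nc2ccc(F)cc2c1O`, 51.3%
compound 2 `CCOc1ccc2nc(C(=O)Nc3c(F)cc(-c4cccc(F)c4)cc3F)c(C)c(O)c2c1`, 37.9%

Among the compounds with values here, in a functional assay on A-375 cells (Homo sapiens) for antiproliferative activity, read by MTT assay, with a stated time of 24 h, tested at 100 ug/mL (a higher number here means a stronger effect of the compound at the concentration tested, a lower number a weaker effect), compound 2 stands lowest of the two numbers, with compound 1 the only neighbour, and the one step recorded is a number 13.4 percentage points lower from compound 1 to compound 2 (beyond the scatter). Compound 3 `Cc1c(C(=O)Nc2c(F)cc(-c3cccc(F)c3)cc2F)nc2ccc(OC(F)(F)F)cc2c1O` differs from compound 2 by trifluoromethyl in place of ethyl on an oxygen on an aromatic ring. Within the data shown here, no measured step covers this exchange on the oxygen; the single step concerns a different change, so it gives only a loose anchor. Compound 3 is therefore expected to stay close to compound 2, with a number 7.1 percentage points higher from compound 2 to compound 3 (within the scatter) estimated. The estimate for compound 3 is 45%, within 25% to 65%.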

Compound 3, a percentage reported as inhibition, at one concentration (the size of the read-out at that concentration, not a potency): 25.6%
The estimate for compound 3 lay 19.4 percentage points above the measured number, within the range that was stated.
By their numbers in this assay, from the lowest: compound 3; then compound 2; then compound 1.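

In this assay the exchange of ethyl for trifluoromethyl on the oxygen gives a number 12.3 percentage points lower from compound 2 to compound 3 (beyond the scatter) and so shows that the group carried by that oxygen itself changes the read-out, which the earlier step from fluoro to ethoxy could not separate. Set against fluoro on the same aromatic carbon, trifluoromethoxy gives a number 25.7 percentage points lower from compound 1 to compound 3 (beyond the scatter) and is the largest step seen at this position. Going by these compounds, whether an amine, a carboxylic acid or a longer chain on the oxygen would restore the effect stays open. Nothing at hand explains these differences.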